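A few compounds are considered here, and "the series" means these few. Any claim that something is new, unique, unknown or untested is made for them only; others in the source may bear on it.

Of the compounds shown here, two so far have a reading in an ADME assay on the whole organism (plasma, strain Sprague-Dawley) for pharmacokinetics, with Rattus norvegicus as the target, read by LC-MS, at a dose of 10 mg/kg by the oral route (on this read-out higher numbers stand for higher exposure at the dose given and lower numbers for lower exposure), and they sit well apart. Compound 1 `CC(C)(C)c1cc(NC(=O)Nc2ccc(NC(=O)c3ccc(OC4CCN(C5CC5)CC4)cn3)cc2)no1` gives 4930 ng.h/mL while compound 2 `CCN1CCC(Cc2ccc(C(=O)Nc3ccc(NC(=O)Nc4cc(C(C)(C)C)on4)cc3)nc2)CC1` gives 707 ng.h/mL as the lower of the two numbers. Compound 3 `CC(C)N1CCC(Oc2ccc(C(=O)Nc3ccc(NC(=O)Nc4cc(C(C)(C)C)on4)cc3)nc2)CC1` differs from compound 2 by carrying (1-isopropylpiperidin-4-yl)oxy in place of (1-ethylpiperidin-4-yl)methyl on an aromatic carbon. Going by the values given here, only one measured step bears on this change. It is a 7.0-fold lower number from compound 1 to compound 2 (0.84 log units; beyond the scatter) and there (1-ethylpiperidin-4-yl)methyl took the place of (1-cyclopropylpiperidin-4-yl)oxy. The new change runs nearly back along that step, though isopropyl is not the cyclopropyl of compound 1 and no measurement compares those two groups. A rise beyond the scatter but somewhat smaller is therefore expected in this assay (a 4.2-fold higher number from compound 2 to compound 3 (0.63 log units; beyond the scatter)). For compound 3 the estimated value is 3000 ng.h/mL (expected range 1000 ng.h/mL to 9000 ng.h/mL).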

Compound 3, area under the concentration-time curve: 1820 ng.h/mL
Compound 3: the middle estimate sits 1.6-fold (0.22 log units) above what was measured, within the range that was stated.
By their numbers in this assay, from the lowest: compound 2; then compound 3; then compound 1.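

this assay is the only read-out here. Both new steps concern exposure after an oral dose. With the oxygen-linked piperidine kept, changing only the group on the amine nitrogen still matters: there is a 2.7-fold lower number from compound 1 to compound 3 (0.43 log units; beyond the scatter) when isopropyl replaces cyclopropyl, so the linking atom cannot account for the whole gap between compound 1 and compound 2. Going the other way, there is a 2.6-fold higher number from compound 2 to compound 3 (0.41 log units; beyond the scatter) on replacing (1-ethylpiperidin-4-yl)methyl with (1-isopropylpiperidin-4-yl)oxy, but that swap alters both the link and the nitrogen group, and nothing in the data given explains either step.

On these data alone, the share of the link alone stays open, and (1-ethylpiperidin-4-yl)oxy would separate it from the nitrogen group. Whether a methyl or a tert-butyl on that nitrogen would follow the same trend is also unknown.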